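A Bromo for a Methoxy in a Level Series

A few compounds are considered here, and "the series" means these few. Any claim that something is new, unique, unknown or untested is made for them only; others in the source may bear on it.

In a functional assay on HCT-116 cells (Homo sapiens) for inhibition, read by colorimetric assay, with a stated time of 3 days (on this read-out lower numbers stand for stronger inhibition and higher numbers for weaker inhibition), compound 1 (`O=C(CCCCCCNC(=O)C(O)(O)C(F)(F)F)Nc1ccncc1`) gives 6670 nM and compound 2 (`COc1ccc(NC(=O)CCCCCCNC(=O)C(O)(O)C(F)(F)F)cc1`) gives 4520 nM while compound 3 (`COc1cccc(NC(=O)CCCCCCNC(=O)C(O)(O)C(F)(F)F)c1`) gives 6110 nM in the same range. Compound 3 has no separate place among the three, with a 1.4-fold higher number from compound 2 to compound 3 (0.13 log units; within the scatter) and a 1.1-fold lower number from compound 1 to compound 3 (0.04 log units; within the scatter) as its links to the others. Compound 4 (`O=C(CCCCCCNC(=O)C(O)(O)C(F)(F)F)Nc1cccc(Br)c1`) keeps the shared core and carries bromo in place of methoxy on an aromatic carbon so that 3-bromophenyl replaces 3-methoxyphenyl. Among the measured compounds shown here, no measured compound carries bromo, so the only guide is the size of the replacements already made on the amide-type nitrogen. Even the exchange seen in a 1.5-fold lower number from compound 1 to compound 2 (0.17 log units; within the scatter) stays small, so no step beyond the scatter is expected in this assay here. The estimated change is a 1.4-fold lower number from compound 3 to compound 4 (0.13 log units; within the scatter) and thus no real separation. Compound 4 is expected at 4500 nM with an estimated range from 2200 nM to 9000 nM when it is measured.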

Compound 4, half-maximal inhibitory concentration: 3060 nM
Estimate against measurement, compound 4: 1.5-fold (0.17 log units) above, within the range that was stated.
By their numbers in this assay, from the lowest: compounds 4, 2, 3 and 1 (each within the scatter of the next, the first and the last beyond it).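

At this aromatic carbon, bromo in place of methoxy gives a 2.0-fold lower number from compound 3 to compound 4 (0.30 log units; within the scatter), so in this assay this exchange stays within the scatter, as the steps among the first three compounds did. Among the compounds shown here, the link to the other methoxy compound, a 1.5-fold lower number from compound 2 to compound 4 (0.17 log units; within the scatter), also shows no separation, but a 2.2-fold lower number from compound 1 to compound 4 (0.34 log units; beyond the scatter) is the first step to pass the scatter, if only modestly, and it sets 3-bromophenyl apart from pyridin-4-yl on the amide-type nitrogen, which neither methoxyphenyl group did. Nothing available explains this step.

The compounds shown leave open what a chloro, a nitrile or an amine would give on this same aromatic carbon. They also leave open whether a longer chain in the shared core would move the numbers further than these aromatic exchanges have.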